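A few compounds are considered here, and "the series" means these few. Any claim that something is new, unique, unknown or untested is made for them only; others in the source may bear on it.

Measured so far:
compound 1 `Cc1cc(-c2cc(F)cc(F)c2)cc(C)c1Nc1ccnc(Nc2ccc(C#N)cc2)n1`: 3910 nM
compound 2 `Cc1cc(C)cc(-c2cc(C)c(Nc3ccnc(Nc4ccc(C#N)cc4)n3)c(C)c2)c1`: 4140 nM

In an ADME assay on MT4 cells (Homo sapiens) for cytotoxicity, read by MTT assay, with a stated time of 4 days (a lower number here means that less compound is tolerated, a higher number that more compound is tolerated), compound 2 holds the highest of the two numbers, but its nearest neighbour, compound 1, stands within the scatter of it, so no order between the two can be claimed. For the measured compounds named here, the single measured step, a 1.1-fold higher number from compound 1 to compound 2 (0.02 log units; within the scatter), exchanged one distal aryl for another and left the number essentially unchanged.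

Compound 3 `Cc1cccc(-c2cc(C)c(Nc3ccnc(Nc4ccc(C#N)cc4)n3)c(C)c2)c1` differs from compound 2 by hydrogen in place of methyl on an aromatic carbon. Going by the values given here, no measured step removes a single methyl from that ring; the only comparison that bears on the distal aryl is the step from compound 1 to compound 2, and it was within the scatter. On that basis the expected step of a 1.0-fold lower number from compound 2 to compound 3 (0.01 log units; within the scatter) in this assay is none beyond the scatter. Compound 3 is therefore estimated at 4000 nM, with a range from 2000 nM to 8500 nM.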

Compound 3, half-maximal cytotoxic concentration: 3670 nM
Estimate against measurement, compound 3: 1.1-fold (0.04 log units) above; low and high end bracket the measured number.
By their numbers in this assay, from the lowest: compounds 3, 1 and 2 (each within the scatter of the next).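

With hydrogen in place of one methyl on the distal aryl in this assay the step reads a 1.1-fold lower number from compound 2 to compound 3 (0.05 log units; within the scatter) and so, at this place meta to a large group, a single methyl makes no readable difference. For the compounds shown here, the earlier compounds compared only two distal rings carrying two substituents each, whereas the exchange of 3,5-difluorophenyl for 3-methylphenyl reads a 1.1-fold lower number from compound 1 to compound 3 (0.03 log units; within the scatter) and brings in a ring with one substituent. All three distal aryl groups therefore remain indistinguishable in this assay and no order among them can be given.

Going by these compounds, whether an amine or a carboxylic acid on this ring, or hydrogen in place of the remaining methyl, would give a step beyond the scatter stays open. No evidence at hand bears on this flat reading.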